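A few compounds are considered here, and "the series" means these few. Any claim that something is new, unique, unknown or untested is made for them only; others in the source may bear on it.

Compound 1 `NC(=O)C(N)CCSCCCCC(=O)O` gives 17% in an assay on isolated protein for inhibition of betaine--homocysteine S-methyltransferase 1 (Homo sapiens), with a stated time of 30 min, tested at 20 uM; on this read-out higher numbers stand for more inhibition at the one concentration tested (going by the name of the read-out) and lower numbers for less inhibition. Compound 2 `COC(=O)C(N)CCSCCCCC(=O)O` has "not determined" (no result reported) in this assay. Compound 3 `NC(CCSCCCCC(=O)O)c1nnn[nH]1` gives 0% in this assay, the lowest of the two numbers reported, the only shown step being a number 17 percentage points lower from compound 1 to compound 3 (beyond the scatter). Compound 4 `NC(CCSCCCCC(=O)O)c1nc(=O)o[nH]1` differs from compound 3 by a group of 6 heavy atoms (2 carbon, 2 nitrogen, 2 oxygen; one five-membered aromatic ring with 3 hetero atoms) in place of a group of 5 heavy atoms (1 carbon, 4 nitrogen; one five-membered aromatic ring with 4 hetero atoms), on a saturated chain carbon bound to an amine nitrogen and a saturated chain carbon. Among the measured compounds shown here, no measured step exchanges one five-membered aromatic ring for another, so the one step that bears on the change, from carbamoyl to the tetrazolyl ring, only shows that a modest loss followed that exchange and that compound 3 sits at the floor of the read-out. Compound 4 is therefore expected to stay near compound 3, with an estimated step of a number 3 percentage points higher from compound 3 to compound 4 (within the scatter), within the scatter, giving an estimate of 3% for compound 4 in this assay, ranging from 0% to 15%.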

Compound 4, a percentage reported as inhibition, at one concentration (the size of the read-out at that concentration, not a potency): 15%
Compound 4: the middle estimate sits 12 percentage points below what was measured; the measured number falls inside the stated range.
By their numbers in this assay, from the lowest: compound 3; then compounds 4 and 1 (each within the scatter of the next).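

In this assay the exchange of 1H-tetrazol-5-yl for the other five-membered aromatic ring, on a saturated chain carbon bound to an amine nitrogen and a saturated chain carbon, gives a number 15 percentage points higher from compound 3 to compound 4 (beyond the scatter), so the loss seen with the tetrazole does not extend to every five-membered aromatic ring at this place. The carbamoyl group can also give way to a ring here without a clear change, with a number 2 percentage points lower from compound 1 to compound 4 (within the scatter). No measurement shown accounts for the difference between the two rings. Going by these compounds, whether a carboxylic acid in place of the ring would match these numbers remains open, as does how either ring would fare at other concentrations.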